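Capping group exchange on compound 2: plasma stability notes

The source may hold more compounds than are shown below. What is called first, only, known or untested is meant among the compounds shown, and "the series" means these compounds.

Two members of the series have numbers in an ADME assay on a cell-free system (plasma, Homo sapiens) for metabolic stability; on this read-out higher numbers stand for a longer-lived compound and lower numbers for a shorter-lived compound. Compound 1 `COC(=O)C12CC1CCN(C(=O)[C@H](CC(C)C)NC(=O)[C@H](CO)NC(=O)[C@@H](NC(=O)C1=CCCNC1)C(C)C)C2` gives 4.92 h in this assay. Compound 2 `COC(=O)C12CC1CCN(C(=O)[C@H](CC(C)C)NC(=O)[C@H](CC(C)C)NC(=O)[C@H](CC(C)C)NC(=O)OCc1ccccc1)C2` gives 3.22 h in this assay, the lower of the two numbers, with compound 1 at a gap that lies within the scatter, so no order between the two can be read from them.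

Compound 3 `COC(=O)C12CC1CCN(C(=O)[C@H](CC(C)C)NC(=O)[C@H](CC(C)C)NC(=O)[C@H](CC(C)C)NC(=O)C1=CCCNC1)C2` is not yet measured. Its difference from compound 2 is a group of 6 heavy atoms (5 carbon, 1 nitrogen; one six-membered non-aromatic ring with 1 hetero atom) in place of a group of 8 heavy atoms (7 carbon, 1 oxygen; one six-membered aromatic ring of carbon only), on a carbonyl carbon, in words a group of 6 heavy atoms (5 carbon, 1 nitrogen; one six-membered non-aromatic ring with 1 hetero atom) in place of a group of 8 heavy atoms (7 carbon, 1 oxygen; one six-membered aromatic ring of carbon only), on a carbonyl carbon. Compound 1 carries that same entering group on the shared core and gives 4.92 h, which gives a rough anchor.

For compound 3 in this assay the expected step of a 1.2-fold higher number from compound 2 to compound 3 (0.09 log units; within the scatter) is small and not beyond the scatter, if anything upward. The estimate for compound 3 is 4 h, with a range from 2 h to 8 h.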

Compound 3, half-life: > 6 h
Compound 3: no number, only a limit (the forecaster's own chance of this, stated with the estimate: 5%); middle value at least 1.5-fold (0.17 log units) from the limit.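

Compound 3 reaches a limit of this assay at > 6 h, which is a limit and not a number. Among these compounds, on the carbonyl carbon whose other neighbour is the amide-type nitrogen, the entering ring group in place of benzyloxy gives an at least 1.8-fold higher number from compound 2 to compound 3 (0.27 log units; that floor lies within the scatter), the first step at this position, and it shows no shortening of the half-life even though its floor does not clear the scatter. The full size of this step cannot be read because the read-out for compound 3 is capped: the limit of > 6 h in this assay, at which 1 of the 3 values shown sits.

The compounds shown leave open whether the true step from benzyloxy to the entering group goes beyond the scatter, and they do not separate what the ring nitrogen and the double bond each contribute. Going by these compounds, how the half-life reads with other groups on this carbonyl carbon, such as cyclohexyl, a longer alkyl chain or a carboxylic acid, also remains open.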